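The compounds below may be only part of what the source reports. "The series", "measured", "known", "first", "only" and "open" are said of these compounds alone.

Of the compounds shown here, three have been measured in an ADME assay on HEK-293T cells (Homo sapiens) for cytotoxicity, read by MTT assay, with a stated time of 24 h; on this read-out lower numbers stand for higher toxicity in this test and higher numbers for lower toxicity in this test. Compound 1 `Cc1ccccc1C(=O)n1c(-c2cn(-c3ccccc3)nc2-c2ccc(F)cc2)nc2ccccc21` gives 189000 nM, compound 2 `O=C(c1ccncc1)n1c(-c2cn(-c3ccccc3)nc2-c2ccc(F)cc2)nc2ccccc21` gives 151000 nM, and compound 3 `O=C(c1ccncc1)n1c(-c2cn(-c3ccccc3)nc2-c2ccc(C(F)(F)F)cc2)nc2ccccc21` gives 135000 nM. Compound 2 stands second highest of the three numbers, though all three lie within the scatter of one another: a 1.1-fold lower number from compound 2 to compound 3 (0.05 log units; within the scatter) separates it from its nearest neighbour, and a 1.3-fold lower number from compound 1 to compound 2 (0.10 log units; within the scatter) from its furthest. Compound 4 `Cc1cccc(C(=O)n2c(-c3cn(-c4ccccc4)nc3-c3ccc(F)cc3)nc3ccccc32)c1` differs from compound 2 by 3-methylphenyl in place of pyridin-4-yl on a carbonyl carbon. The step that bears on this change is a 1.3-fold lower number from compound 1 to compound 2 (0.10 log units; within the scatter), the same kind of swap run the other way, which stayed within the scatter, so no step beyond the scatter is expected in this assay. Compound 4 is therefore estimated at 180000 nM, between 90000 nM and 360000 nM, an expected step of a 1.2-fold higher number from compound 2 to compound 4 (0.08 log units; within the scatter).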

Compound 4, half-maximal cytotoxic concentration: 148000 nM
Compound 4: the middle estimate sits 1.2-fold (0.09 log units) above what was measured; the measured number falls inside the stated range.
By their numbers in this assay, from the lowest: compounds 3, 4, 2 and 1 (each within the scatter of the next).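

In this assay the carbonyl carbon now carries a third aromatic group: 3-methylphenyl in place of pyridin-4-yl gives a 1.0-fold lower number from compound 2 to compound 4 (0.01 log units; within the scatter) and 3-methylphenyl in place of 2-methylphenyl gives a 1.3-fold lower number from compound 1 to compound 4 (0.11 log units; within the scatter). Neither the ring nitrogen nor the placing of the methyl on the ring therefore produces a step beyond the scatter among these compounds. Nothing available explains this flat result. Still open, going by these compounds, is whether an amine or a carboxylic acid on this ring would shift the number, or a longer alkyl chain in place of the ring.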